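A few compounds are considered here, and "the series" means these few. Any claim that something is new, unique, unknown or untested is made for them only; others in the source may bear on it.

Going by the values given here, compound 1 `Cc1cc(O)c(C2=NN(c3ccc(S(N)(=O)=O)cc3)C(c3ccccc3Cl)C2)cc1Cl` and compound 2 `COc1ccc(C2CC(c3cc(Cl)c(C)cc3O)=NN2c2ccc(S(N)(=O)=O)cc2)cc1OC` are the two measured members. In a functional assay on NCI-H522 cells (Homo sapiens) for antiproliferative activity, with a stated time of 48 h (on this read-out higher numbers stand for lower toxicity in this test and lower numbers for higher toxicity in this test), compound 1 gives 8330 nM and compound 2 gives 69300 nM. Among the compounds with values here, compound 2 stands highest of the two numbers; the only step known is an 8.3-fold higher number from compound 1 to compound 2 (0.92 log units; beyond the scatter).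

Compound 3 `COc1ccc(C2CC(c3cc(Cl)c(C)cc3O)=NN2c2ccc(S(N)(=O)=O)cc2)c(OC)c1OC` differs from compound 2 by methoxy in place of hydrogen on an aromatic carbon. Within the data shown here, no measured step covers an added methoxy on this ring, and the step from compound 1 to compound 2 concerns a different change, so it offers no direct guide. The expectation for compound 3 is therefore a step of no more than the scatter, a 1.2-fold lower number from compound 2 to compound 3 (0.06 log units; within the scatter). Compound 3 is estimated at 60000 nM, range 25000 nM to 150000 nM.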

Compound 3, concentration lethal to 50% of the cells: 25800 nM
Compound 3: middle estimate off by 2.3-fold (0.37 log units), on the high side; the measured number falls inside the stated range.
By their numbers in this assay, from the lowest: compound 1; then compound 3; then compound 2.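

In this assay, methoxy in place of hydrogen on an aromatic carbon, ortho to a large group and ortho to a methoxy group, is not a silent change (a 2.7-fold lower number from compound 2 to compound 3 (0.43 log units; beyond the scatter)). The 2,3,4-trimethoxyphenyl compound therefore closes part of the gap to the 2-chlorophenyl compound, but a difference remains (a 3.1-fold higher number from compound 1 to compound 3 (0.49 log units; beyond the scatter)). No available evidence bears on the reason for either step.

As far as these compounds go, what a hydroxy group, an amine or a longer alkoxy chain would do on this same ring carbon remains open. Also open, from the compounds shown here alone, is whether methoxy gives a similar step without the other two methoxy groups.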